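Series notes: a second chloro on the chlorophenyl group

The source may hold more compounds than are shown below. What is called first, only, known or untested is meant among the compounds shown, and "the series" means these compounds.

Three compounds of the shared core have a cytotoxicity number in an ADME assay on Vero cells (Chlorocebus sabaeus) for cytotoxicity, read by MTT assay, with a stated time of 72 h; a higher number here means that more compound is tolerated, a lower number that less compound is tolerated. Compound 1 `CCOc1ccc(/C=C/C(=O)c2ccc3c(c2O)C=CC(C)(C)O3)cc1` gives 215000 nM, compound 2 `CC(=O)Nc1ccc(/C=C/C(=O)c2ccc3c(c2O)C=CC(C)(C)O3)cc1` gives 279000 nM, and compound 3 `CC1(C)C=Cc2c(ccc(C(=O)/C=C/c3ccc(Cl)cc3)c2O)O1` gives 92200 nM. Compound 3 stands lowest of the three: a 2.3-fold lower number from compound 1 to compound 3 (0.37 log units; beyond the scatter) and a 3.0-fold lower number from compound 2 to compound 3 (0.48 log units; beyond the scatter) both lie beyond the scatter, whereas a 1.3-fold higher number from compound 1 to compound 2 (0.11 log units; within the scatter) does not. Compound 4 `CC1(C)C=Cc2c(ccc(C(=O)/C=C/c3ccc(Cl)c(Cl)c3)c2O)O1` differs from compound 3 by chloro in place of hydrogen on an aromatic carbon. Among the measured compounds shown here, no measured step adds a second chloro group; the nearest guides are the steps that put one chloro group in place of ethoxy or acetamido, a 2.3-fold lower number from compound 1 to compound 3 (0.37 log units; beyond the scatter) and a 3.0-fold lower number from compound 2 to compound 3 (0.48 log units; beyond the scatter), both modest drops. In this assay a further modest drop, or none beyond the scatter, is therefore expected. Compound 4 is estimated at 65000 nM, between 32000 nM and 130000 nM, an expected step of a 1.4-fold lower number from compound 3 to compound 4 (0.15 log units; within the scatter).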

Compound 4, half-maximal cytotoxic concentration: 142000 nM
The estimate for compound 4 lay 2.2-fold (0.34 log units) below the measured number, and the stated range ends below it.
By their numbers in this assay, from the lowest: compounds 3, 4, 1 and 2 (each within the scatter of the next, the first and the last beyond it).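

At the aromatic carbon ortho to a chloro group, going from 4-chlorophenyl to 3,4-dichlorophenyl gives in this assay a 1.5-fold higher number from compound 3 to compound 4 (0.19 log units; within the scatter). A second chloro at this position therefore does not extend the modest drops seen when one chloro replaced ethoxy or acetamido. Nothing available explains this step.

The compounds shown leave open whether a methoxy group, an amine or a carboxylic acid on this same carbon would also stay within the scatter of compound 3.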